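Phenoxy in Place of Chloro on the Benzyl Ether of Compound 2

The source may report more compounds than this note shows. Statements on the series, on what has been measured and on what is new or still open speak of the compounds shown alone.

Of the compounds shown here, three sharing one core have been tested in an assay on CHO cells for binding affinity to metabotropic glutamate receptor 2 (Rattus norvegicus); a lower number here means a stronger inhibitor, a higher number a weaker inhibitor. Compound 1 `N[C@]1(C(=O)O)[C@H]2[C@@H](C[C@H]1OCc1ccccc1Cl)[C@]2(F)C(=O)O` gives 4.99 nM, compound 2 `N[C@]1(C(=O)O)[C@H]2[C@@H](C[C@H]1OCc1cccc(Cl)c1)[C@]2(F)C(=O)O` gives 3.28 nM, and compound 3 `N[C@]1(C(=O)O)[C@H]2[C@@H](C[C@H]1OCc1ccccc1-c1ccccc1)[C@]2(F)C(=O)O` gives 4.07 nM. Compound 2 holds the lowest of the three numbers, but the gaps to compound 3 and to compound 1 both fall within the scatter, so no order among the three can be read from these values.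

Compound 4 `N[C@]1(C(=O)O)[C@H]2[C@@H](C[C@H]1OCc1cccc(Oc3ccccc3)c1)[C@]2(F)C(=O)O` differs from compound 2 by phenoxy in place of chloro on an aromatic carbon. Going by the values given here, two measured steps bear on this change. Moving the chloro around the ring, a 1.5-fold lower number from compound 1 to compound 2 (0.18 log units; within the scatter), left the number within the scatter. Replacing chloro by an aromatic ring, a 1.2-fold lower number from compound 1 to compound 3 (0.09 log units; within the scatter), also stayed within the scatter. Among the compounds with values here, the change to compound 4 combines a ring-bound oxygen with an aromatic ring, for which no direct precedent exists among the measured compounds.

Compound 4 is therefore expected to give 3.8 nM, within a range from 1.5 nM to 10 nM. The expected step, a 1.2-fold higher number from compound 2 to compound 4 (0.06 log units; within the scatter), is no change beyond the scatter.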

Compound 4, inhibition constant: 7.15 nM
The estimate for compound 4 lay 1.9-fold (0.27 log units) below the measured number; the measured number falls inside the stated range.
By their numbers in this assay, from the lowest: compounds 2, 3, 1 and 4 (each within the scatter of the next, the first and the last beyond it).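

In this assay, phenoxy in place of chloro on this aromatic carbon gives the first step among these compounds to pass beyond the scatter (a 2.2-fold higher number from compound 2 to compound 4 (0.34 log units; beyond the scatter)), although the step is modest. The two earlier steps showed no readable change, whereas this one shows that the number at this position, meta to a large group, can respond when a single chlorine gives way to phenoxy, with its seven heavy atoms, aromatic ring and hydrogen-bond acceptor. No available data bear on the reason for this step.

The compounds shown leave open whether the step belongs to the oxygen or to the aromatic ring, which enter together in compound 4. Also open, on these data alone, is how the number at this position would respond to a directly attached phenyl, a benzyloxy group, an amine or a carboxylic acid in place of the chloro.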